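The source may report more compounds than this note shows. Statements on the series, on what has been measured and on what is new or still open speak of the compounds shown alone.

In an ADME assay on microsomes from liver (Homo sapiens) for metabolic stability, read by LC-MS, using NADPH, with a stated time of 10 min, tested at 10 uM (on this read-out higher numbers stand for a longer-lived compound and lower numbers for a shorter-lived compound), compound 2 `Nc1ncnc2c1c(Oc1cc(C(F)(F)F)ccn1)nn2CC1CC1` gives 1.87 h, which lies within the scatter of compound 3 `Nc1ncnc2c1c(Oc1cccc(C(F)(F)F)c1)nn2[C@H]1C[C@H](O)C1` at 1.25 h. Compound 1 `Nc1ncnc2c1c(Oc1cc(C(F)(F)F)ccn1)nn2C1CC1` reports only a limit, > 2.41 h. Compound 4 `Nc1ncnc2c1c(Oc1cc(C(F)(F)F)ccn1)nn2C1CCCCC1` has not yet been measured. It carries cyclohexyl in place of cyclopropylmethyl on an aromatic nitrogen, (cyclohexyl in place of cyclopropylmethyl on an aromatic nitrogen). For the measured compounds named here, only one measured step bears on this change, cyclopropylmethyl in place of cyclopropyl on that same nitrogen, and it reads an at least 1.2-fold lower number from compound 1 to compound 2 (0.11 log units; that floor lies within the scatter). That single small step is a thin guide, so no change beyond the scatter is expected. The estimated step is a 1.4-fold lower number from compound 2 to compound 4 (0.16 log units; within the scatter). For compound 4 the expected half-life is 1.3 h, with an estimated range of 0.55 h to 2.6 h.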

Compound 4, half-life: 0.55 h
Estimate against measurement, compound 4: 2.4-fold (0.37 log units) above; the measured number falls inside the stated range.
By their numbers in this assay, from the lowest: compound 4; then compounds 3 and 2 (each within the scatter of the next). At a limit, above all of these: compound 1.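

In this assay, the group on this aromatic nitrogen can clearly shift the half-life: cyclohexyl in place of cyclopropylmethyl gives a 3.4-fold lower number from compound 2 to compound 4 (0.53 log units; beyond the scatter), whereas the earlier step at this position stayed within the scatter. Cyclohexyl in place of cyclopropyl gives an at least 4.3-fold lower number from compound 1 to compound 4 (0.64 log units; beyond the scatter). That step is only a floor, since compound 1 reports a limit and not a number: the limit of > 2.41 h in this assay, at which 1 of the 4 values shown sits.

The compounds shown leave open whether an open chain such as isopropyl, or a ring holding an oxygen such as tetrahydropyranyl, would behave like cyclohexyl or like cyclopropylmethyl on this nitrogen.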